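Urea Analogues on a Shared Pyrazole-Free Description: Compound 4

This account rests on a few compounds, and the source may have more. Where it says the series, first, only, none or still open, it means among the compounds named here.

Compound 1 `Cc1ccccc1NC(=O)Nc1cc(C(C)(C)C)nn1-c1ccccc1`: 1.2 degrees C
Compound 2 `Cc1ccc(S(=O)(=O)NC(=O)Nc2cc(C(C)(C)C)nn2-c2ccccc2)cc1`: 0.2 degrees C
Compound 3 `Cn1nc(C(C)(C)C)cc1NC(=O)Nc1cc(C(F)(F)F)cc(C(F)(F)F)c1`: 0.4 degrees C

Three ureas have been tested in an assay on isolated protein for inhibition of Ephrin type-A receptor 2 (Homo sapiens), read by thermal shift assay, tested at 10 uM; a higher number here means that the compound stabilises the target more against heat, a lower number that the compound stabilises the target less. Compound 1 holds the highest figure of the three, yet its gap to compound 3 and its gap to compound 2 both fall inside the usual scatter, so the three numbers cannot be ranked. Compound 4 `CC(C)(C)c1cc(NC(=O)Nc2cc(F)cc(F)c2)n(-c2ccccc2)n1` is not yet measured; it differs from compound 1 in one place: 3,5-difluorophenyl in place of 2-methylphenyl on an amide-type nitrogen. For the measured compounds named here, no measured pair isolates this change, so no step size is known. On these data the author expects no step beyond the scatter from compound 1 to compound 4 in this assay, that is a number 0.40 degrees C lower from compound 1 to compound 4 (within the scatter). Compound 4 is therefore estimated at 0.8 degrees C, in the range -0.5 degrees C to 2 degrees C.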

Compound 4, shift of the target's melting temperature: 2.7 degrees C
Compound 4: the middle estimate sits 1.9 degrees C below what was measured; the measured number lies above the stated range.
By their numbers in this assay, from the lowest: compounds 2, 3 and 1 (each within the scatter of the next); then compound 4.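

In this assay, the aryl group on this amide-type nitrogen proves able to shift the number: 3,5-difluorophenyl in place of 2-methylphenyl gives a number 1.5 degrees C higher from compound 1 to compound 4 (beyond the scatter), the only listed step that exceeds the scatter. Nothing measured here explains this step. The change removes the methyl and adds both fluorines at once, so the compounds shown do not separate these contributions. From the compounds shown here alone, what a 3-fluorophenyl or a 3,5-dichlorophenyl group would give on the same nitrogen remains open.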